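Methoxy in place of fluoro: what to expect of compound 3

This account rests on a few compounds, and the source may have more. Where it says the series, first, only, none or still open, it means among the compounds named here.

Within the data shown here, compound 2 `O=C1/C(=C\c2ccc(F)cc2)c2ccccc2N1c1c(Cl)cccc1Cl` is the only compound with a number in a functional assay on L132 cells (Homo sapiens) for cytotoxicity, read by MTT assay, with a stated time of 72 h (on this read-out lower numbers stand for an effect already at smaller amounts and higher numbers for an effect only at larger amounts of compound), where compound 2 gives 13 ug/mL. Compound 1 `O=C1/C(=C\c2c(Cl)cccc2Cl)c2ccccc2N1c1c(Cl)cccc1Cl` sits at the limit of > 100 ug/mL in this assay, at which 1 of the 2 values shown sits; the value of compound 1, > 100 ug/mL, is a limit of this assay and not a number. Among the measured compounds shown here, the single measured step, an at least 7.6-fold lower number from compound 1 to compound 2 (0.88 log units; beyond the scatter), altered the same aromatic ring but not the same group, so it bears only loosely on the present change. Compound 3 `COc1ccc(/C=C2\C(=O)N(c3c(Cl)cccc3Cl)c3ccccc32)cc1` carries methoxy in place of fluoro on an aromatic carbon. The step expected in this assay, a 1.2-fold higher number from compound 2 to compound 3 (0.06 log units; within the scatter), is none beyond the scatter. Compound 3 is therefore estimated at 15 ug/mL, within 5 ug/mL to 45 ug/mL.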

Compound 3, concentration for half-maximal effect: > 100 ug/mL
Compound 3: no number, only a limit; the forecaster's own chance of this, stated with the estimate: 15%; at least 6.6-fold (0.82 log units) between middle value and limit.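

In this assay methoxy in place of fluoro gives an at least 7.6-fold higher number from compound 2 to compound 3 (0.88 log units; beyond the scatter), so exchanging this one small group, para to a large group, is enough to move the read-out while the rest of the molecule stays the same. The value of compound 3 is a limit and not a number, and it shares that limit with compound 1: the limit of > 100 ug/mL in this assay, at which 2 of the 3 values shown sit. The step from compound 1 to compound 3 cannot be read.

Still open, from the compounds shown here alone, is whether chloro, hydroxyl or an amine at this place would give a number in this assay. Also open, going by these compounds, is how far the true value of compound 3 lies past its limit.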